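A few compounds are considered here, and "the series" means these few. Any claim that something is new, unique, unknown or untested is made for them only; others in the source may bear on it.

Two compounds of this series have been run in a functional assay on HEL cells (Homo sapiens); on this read-out lower numbers stand for higher toxicity in this test and higher numbers for lower toxicity in this test. Compound 1 `Nc1nc(O)c2ncn([C@H]3C[C@@H](O)[C@@H](O)C3)c2n1` gives 196 ug/mL in this assay. Compound 2 `Nc1ncnc2c1ncn2[C@H]1C[C@@H](O)[C@@H](O)C1` gives 110 ug/mL in this assay. Compound 2 carries the smaller of the two numbers, yet its gap to compound 1 falls within the usual scatter of repeated measurements, so the two cannot be told apart on this read-out.

Compound 3 `Nc1nc(N)c2ncn([C@H]3C[C@@H](O)[C@@H](O)C3)c2n1` has not yet been measured in this assay. It differs from compound 2 in one place: amino in place of hydrogen on an aromatic carbon. Going by the values given here, no step between measured compounds bears on a change of this kind, so there is nothing to scale an expectation against; the two numbers in hand lie close together and offer no lead in either direction. The expected step is therefore small, a 1.1-fold lower number from compound 2 to compound 3 (0.04 log units; within the scatter), with no preferred direction beyond the scatter. Compound 3 is estimated at 100 ug/mL, with a range of 40 ug/mL to 250 ug/mL.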

Compound 3, minimum cytotoxic concentration: 139 ug/mL
Beside the measured number, compound 3's estimate is 1.4-fold (0.14 log units) below it; the range from low to high includes it.
By their numbers in this assay, from the lowest: compounds 2, 3 and 1 (each within the scatter of the next).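

In this assay, amino in place of hydrogen on the aromatic carbon between two ring nitrogen atoms gives a 1.3-fold higher number from compound 2 to compound 3 (0.10 log units; within the scatter) and stays within the scatter. Amino in place of hydroxy on an aromatic carbon gives a 1.4-fold lower number from compound 1 to compound 3 (0.15 log units; within the scatter) and also stays within the scatter, so compound 3 cannot be told apart from compound 1 or compound 2 on this read-out, and neither change has a detectable effect in these three compounds. Nothing available here bears on why these numbers come out as they do.

On these data alone, whether a methylamino, a dimethylamino or a chlorine on the carbon between the two ring nitrogen atoms would give a step beyond the scatter stays open. Changes to the two hydroxy groups outside the aromatic part of the shared core also remain open.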